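Benzyl amide of a dimethoxy acid: an expected paw-edema result

The compounds below may be only part of what the source reports. "The series", "measured", "known", "first", "only" and "open" are said of these compounds alone.

Measured compounds in a functional assay on the whole organism (strain Wistar) for inhibition, with Rattus norvegicus as the target, read by paw edema, with stated times of 60 min and 3 h, at a dose of 100 mg/kg by the oral route; a lower number here means less inhibition, a higher number more inhibition at the dose given (going by the name of the read-out):
compound 1, `COc1cc2c(cc1OC)C(CC(=O)O)CC2`, gives 27.5%;
compound 2, `CCCNC(=O)CC1CCc2cc(OC)c(OC)cc21`, gives 29%;
compound 3, `COc1cc2c(cc1OC)C(CC(=O)NC1CCCCC1)CC2`, gives 49.3%.

Compound 2 holds the second highest of the three numbers. Its nearest neighbour is compound 1, and that difference, a number 1.5 percentage points higher from compound 1 to compound 2 (within the scatter), lies within the scatter. The furthest is compound 3, and that step, a number 20.3 percentage points higher from compound 2 to compound 3 (beyond the scatter), lies beyond the scatter, though it is modest.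

Compound 4, `COc1cc2c(cc1OC)C(CC(=O)NCc1ccccc1)CC2`, has not yet been measured in this assay. It differs from compound 2 by phenyl in place of ethyl on a saturated chain carbon bound to an amide-type nitrogen; read one bond further out, propylamino becomes benzylamino. Among the compounds with values here, the measured step that bears on this is the one from compound 2 to compound 3, where a ring replaced a short chain on the amide nitrogen and the number rose by a number 20.3 percentage points higher from compound 2 to compound 3 (beyond the scatter). The step from compound 1 to compound 3, a number 21.8 percentage points higher from compound 1 to compound 3 (beyond the scatter), points the same way, while the step from compound 1 to compound 2 stays within the scatter. A six-membered ring on the amide side is therefore expected to raise the number modestly.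

For compound 4 the expected value in this assay is 42%, between 28% and 56%. The expected step is a number 13 percentage points higher from compound 2 to compound 4 (beyond the scatter).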

Compound 4, a percentage reported as inhibition, in the whole organism at one dose (the size of the read-out at that dose, not a potency): 14.5%
Estimate against measurement, compound 4: 27.5 percentage points above, outside the stated range (below it).
By their numbers in this assay, from the lowest: compound 4; then compounds 1 and 2 (each within the scatter of the next); then compound 3.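

In this assay, a ring on the amide side does not by itself carry the number upward: benzyl in place of cyclohexyl on the amide-type nitrogen gives a number 34.8 percentage points lower from compound 3 to compound 4 (beyond the scatter), the largest step in the series, so the two ring-bearing groups give clearly different results at this place. Phenyl in place of ethyl on the saturated chain carbon bound to that nitrogen gives a number 14.5 percentage points lower from compound 2 to compound 4 (beyond the scatter), a fall at a position where the earlier compounds had shown only a rise or no readable change. Benzylamino in place of hydroxy on the carbonyl carbon gives a number 13 percentage points lower from compound 1 to compound 4 (beyond the scatter), which makes compound 4 the only amide shown that falls below the acid, so the change from acid to amide has no single direction across these compounds. Nothing in the data given accounts for this fall.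

The compounds shown leave open whether the fall follows the aromatic ring or the chain carbon that carries it, as benzyl differs from cyclohexyl in both respects, and a cyclohexylmethyl group on the amide nitrogen would separate the two. Also open, going by these compounds, is how a phenethyl group, with its longer chain, would read here.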